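A Dichlorophenyl Carbamoyl Analogue Awaits Its Cytotoxicity Reading

A few compounds are considered here, and "the series" means these few. Any claim that something is new, unique, unknown or untested is made for them only; others in the source may bear on it.

Of the compounds shown here, three built on one shared core have so far been tested in a functional assay on PANC-1 cells (Homo sapiens) for inhibition, read by MTT assay, with a stated time of 24 h, tested at 10 uM; a higher number here means more inhibition at the concentration tested (going by the name of the read-out), a lower number less inhibition. Compound 1, `CC(C)=CCC1Cc2c(OCCCNS(=O)(=O)c3ccc([N+](=O)[O-])cc3)cc(=O)n(CCCO)c2CC1(C)C`, gives 47.7% in this assay. Compound 2, `CC(C)=CCC1Cc2c(OCCCOc3ccc([N+](=O)[O-])cc3)cc(=O)n(CCCO)c2CC1(C)C`, gives 47.5%. Compound 3, `COc1cccc(NC(=O)Oc2cc(=O)n(CCCO)c3c2CC(CC=C(C)C)C(C)(C)C3)c1`, gives 16.2%, the lowest of the three numbers; its nearest neighbour is compound 2, whose number lies higher by a gap beyond the usual scatter, and compound 1 lies a little further still, also beyond the scatter. No two of these compounds differ in only one place, so no single step can be traced between them.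

Compound 4, `CC(C)=CCC1Cc2c(OC(=O)Nc3ccc(Cl)c(Cl)c3)cc(=O)n(CCCO)c2CC1(C)C`, has not yet been measured. It differs from compound 3 in one place: 3,4-dichlorophenyl in place of 3-methoxyphenyl on an amide-type nitrogen. Whether such a change moves the number in this assay cannot be read from compounds 1 and 2, whose differences from compound 3 are of another kind. The expectation is a modest rise with a wide margin: the step of a number 9.8 percentage points higher from compound 3 to compound 4 (within the scatter) is expected to be small and upward, though a step within the scatter, or even a slight fall, would not surprise. Compound 4 is expected to give about 26%, somewhere between 8% and 48%.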

Compound 4, a percentage reported as inhibition, at one concentration (the size of the read-out at that concentration, not a potency): 61.4%
Estimate against measurement, compound 4: 35.4 percentage points below, outside the stated range (above it).
By their numbers in this assay, from the lowest: compound 3; then compounds 2 and 1 (each within the scatter of the next); then compound 4.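

In this assay, the group on the amide-type nitrogen turns out to matter a great deal: 3,4-dichlorophenyl in place of 3-methoxyphenyl gives a number 45.2 percentage points higher from compound 3 to compound 4 (beyond the scatter). Compounds 1 and 2 could not show this, as neither differs from compound 3 in only one place, whereas here the rest of the molecule stays the same and the whole step belongs to this single exchange, in which both groups keep the same count of heavy atoms and one six-membered aromatic ring of carbon, while the oxygen of the methoxy group gives way to two chlorine atoms. No measurement at hand accounts for the size of this step.

From the compounds shown here alone, one pair cannot say whether both chlorine atoms are needed for the step, and it remains open how a plain phenyl ring, a phenyl ring carrying a single chlorine atom, or one carrying a trifluoromethyl group would compare on the same nitrogen. Going by these compounds, it also remains open whether the same exchange would give a similar step with the sulfonamide-bearing chain of compound 1 in place of the carbamoyl link.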